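A few compounds are considered here, and "the series" means these few. Any claim that something is new, unique, unknown or untested is made for them only; others in the source may bear on it.

In a functional assay on SNB-19 cells (Homo sapiens) for inhibition, read by MTT assay, with a stated time of 7 days (a lower number here means a stronger inhibitor of growth, a higher number a weaker inhibitor of growth), compound 1 `COc1ccc([C@@H](C)n2nnc3c(C(N)=O)ncn3c2=O)cc1` reads > 50000 nM, which is a limit of the assay and not a number. Among the measured compounds shown here, compound 2 `C#CC/N=N/Nc1[nH]cnc1C(N)=O` gives 39100 nM, the only actual number so far. Compound 3 `NC(=O)c1nc[nH]c1N/N=N/Cc1ccoc1` differs from compound 2 by one change, furan-3-yl in place of ethynyl on a saturated chain carbon bound to a double-bonded nitrogen. For the measured compounds named here, no measured pair shows such a change yet. The step expected in this assay is a 1.1-fold lower number from compound 2 to compound 3 (0.05 log units; within the scatter), in neither direction beyond the usual scatter. Compound 3 is expected at 35000 nM, with an estimated range of 15000 nM to 50000 nM.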

Compound 3, concentration for 50% growth inhibition: > 50000 nM
Compound 3 gave a limit, no number (the forecaster's own chance of this, stated with the estimate: 30%); middle value at least 1.4-fold (0.15 log units) from the limit.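

On a saturated chain carbon bound to a double-bonded nitrogen, furan-3-yl in place of ethynyl gives an at least 1.2-fold higher number from compound 2 to compound 3 (0.10 log units; that floor lies within the scatter), so this aromatic ring brings no measurable gain in growth inhibition. The value of compound 3 is a limit of the assay and not a number. The true size of the step stays unknown because the reading stops at that limit: the limit of > 50000 nM in this assay, at which 2 of the 3 values shown sit.

Still open, on these data alone, is whether a different group at this place, such as an amine, a carboxylic acid or a longer chain, would give a lower number in this assay.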